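Extending the Ethyl Chain on a Shared Sulfamate Core

This account rests on a few compounds, and the source may have more. Where it says the series, first, only, none or still open, it means among the compounds named here.

Measured so far:
Compound 1 `CC(C)CCN(CCC(C)C)c1ccc(C(=O)N2CCc3ccc(OS(N)(=O)=O)cc3C2)cc1` in an assay on HEK293 cells for inhibition of Steryl-sulfatase (Homo sapiens), tested at 1 uM (on this read-out higher numbers stand for a stronger effect at the one concentration tested and lower numbers for a weaker effect), gives 90.8%
Compound 2 `CCN(Cc1ccc(Br)cc1)c1ccc(C(=O)N2CCc3ccc(OS(N)(=O)=O)cc3C2)cc1` in this assay gives 95.9%
Compound 3 `CCN(Cc1ccccc1)c1ccc(C(=O)N2CCc3ccc(OS(N)(=O)=O)cc3C2)cc1` in this assay gives 83.6%

Compound 3 holds the lowest of the three numbers. Its nearest neighbour is compound 1, as the step of a number 7.2 percentage points lower from compound 1 to compound 3 (within the scatter) shows; its furthest is compound 2, as the step of a number 12.3 percentage points lower from compound 2 to compound 3 (beyond the scatter) shows. Compound 4 `CN(C)CCCN(Cc1ccccc1)c1ccc(C(=O)N2CCc3ccc(OS(N)(=O)=O)cc3C2)cc1` differs from compound 3 by (dimethylamino)methyl in place of hydrogen on a saturated chain carbon, two bonds along the chain from a nitrogen on an aromatic ring.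

All three measured steps change the groups on the same nitrogen of the shared core. Those steps were a number 5.1 percentage points higher from compound 1 to compound 2 (within the scatter), a number 7.2 percentage points lower from compound 1 to compound 3 (within the scatter) and a number 12.3 percentage points lower from compound 2 to compound 3 (beyond the scatter), so even the largest change there moved the number only modestly. None of them adds a (dimethylamino)methyl group, so the expectation rests on the general tolerance these groups have shown. A step of a number 0.4 percentage points higher from compound 3 to compound 4 (within the scatter) is therefore expected, with no movement beyond the scatter. Compound 4 is estimated to give 84% in this assay, within a range from 68% to 95%.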

Compound 4, a percentage reported as inhibition, at one concentration (the size of the read-out at that concentration, not a potency): 61.6%
For compound 4 the middle estimate is 22.4 percentage points above the measured one, and the stated range ends above it.
By their numbers in this assay, from the lowest: compound 4; then compounds 3, 1 and 2 (each within the scatter of the next, the first and the last beyond it).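

Until now, the groups exchanged on this nitrogen carried no second amine. Among the compounds shown here, replacing the ethyl of compound 3 with 3-(dimethylamino)propyl gives, in this assay, a number 22 percentage points lower from compound 3 to compound 4 (beyond the scatter), so the tolerance suggested by the earlier steps does not extend to every group at this position. Nothing available here explains why the number falls.

The compounds shown leave open whether the lower number goes with the longer chain itself or with the dimethylamino group at its end, since this one change introduces both; a plain propyl chain on the same nitrogen would separate the two. From the compounds shown here alone, it also remains open how a different end group on the same chain, such as a hydroxyl or a carboxylic acid, would read in this assay.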